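Adding a cyano group to the phenyl of compound 3

The compounds below may be only part of what the source reports. "The series", "measured", "known", "first", "only" and "open" are said of these compounds alone.

Of the compounds shown here, three sharing one core have been measured in an in vitro ADME assay on microsomes from liver (Homo sapiens) for metabolic stability; a lower number here means slower removal, a higher number faster removal of the compound. Compound 1 `O=C(Nc1cccnc1-c1ccsc1)N1CCN2C(=O)N([C@H]3C[C@@H]3c3ccccc3)C(=O)[C@@H]2C1`, carrying thiophen-3-yl, gives 40000 mL.min-1.g-1. Compound 2 `O=C(Nc1cccnc1-c1cccc(Cl)c1)N1CCN2C(=O)N([C@H]3C[C@@H]3c3ccccc3)C(=O)[C@@H]2C1`, carrying 3-chlorophenyl, gives 90000 mL.min-1.g-1. Compound 3 `O=C(Nc1cccnc1-c1ccccc1)N1CCN2C(=O)N([C@H]3C[C@@H]3c3ccccc3)C(=O)[C@@H]2C1`, carrying phenyl, gives 45000 mL.min-1.g-1, within the usual scatter of both others. Compound 4 `N#Cc1cccc(-c2ncccc2NC(=O)N2CCN3C(=O)N([C@H]4C[C@@H]4c4ccccc4)C(=O)[C@@H]3C2)c1` differs from compound 3 by one change, cyano in place of hydrogen on an aromatic carbon. The nearest guide is the step that puts hydrogen in place of chloro, a 2.0-fold lower number from compound 2 to compound 3 (0.30 log units; within the scatter). The step to 3-chlorophenyl, a 2.3-fold higher number from compound 1 to compound 2 (0.35 log units; beyond the scatter), is only modest. No clear shift in this assay is therefore expected, and the estimated step is a 1.1-fold higher number from compound 3 to compound 4 (0.05 log units; within the scatter). Compound 4 is expected at 50000 mL.min-1.g-1, with an estimated range of 22000 mL.min-1.g-1 to 100000 mL.min-1.g-1.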

Compound 4, intrinsic clearance in microsomes: 37000 mL.min-1.g-1
Compound 4: middle estimate off by 1.4-fold (0.13 log units), on the high side; low and high end bracket the measured number.
By their numbers in this assay, from the lowest: compounds 4, 1, 3 and 2 (each within the scatter of the next, the first and the last beyond it).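

In this assay, adding a nitrile to the phenyl ring, meta to a large group, brings no real change: a 1.2-fold lower number from compound 3 to compound 4 (0.09 log units; within the scatter). Cyano in place of chloro at that same position gives a 2.4-fold lower number from compound 2 to compound 4 (0.39 log units; beyond the scatter), a modest step beyond the scatter, while 3-cyanophenyl in place of thiophen-3-yl gives a 1.1-fold lower number from compound 1 to compound 4 (0.03 log units; within the scatter). Nothing available explains why cyano and chloro differ here. The compounds shown leave open what an amine or a carboxylic acid would do at this position, and whether cyano would behave alike on another carbon of this ring.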